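The source may report more compounds than this note shows. Statements on the series, on what has been measured and on what is new or still open speak of the compounds shown alone.

In an ADME assay on BJ cells (Homo sapiens) for cytotoxicity, with a stated time of 72 h (a lower number here means that less compound is needed, a higher number that more compound is needed for the effect), three compounds have been measured so far, and none of them gives a number. Compound 1 (`Cc1cc(NC(=O)Nc2cccc(C(N)=O)c2)c2ccccc2n1`) reads > 25000 nM as a limit of the assay. Compound 2 (`COc1ccc(NC(=O)Nc2cc(C)nc3ccccc23)cc1OC`) reads > 25000 nM as a limit too. Compound 3 (`Cc1cc(NC(=O)Nc2cnc3ccccc3c2)c2ccccc2n1`) reads > 25000 nM as a limit as well. Compound 1 therefore stands where the whole set stands (the limit of > 25000 nM in this assay, at which 3 of the 3 values shown sit) and has no exact value from which to count.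

Compound 4 (`Cc1cc(NC(=O)Nc2cccc(C(C)(C)C)c2)c2ccccc2n1`) is the next to be read. It carries tert-butyl in place of carbamoyl on an aromatic carbon, on a six-membered aromatic ring of carbon only and meta to a large group (tert-butyl in place of carbamoyl on an aromatic carbon). Going by the values given here, no step between measured compounds is available to size this change, so any expectation is loose. A small move toward a lower number is expected, perhaps none beyond the scatter, and another reading at the limit would be no surprise. The expected move is an at least 1.3-fold lower number from compound 1 to compound 4 (0.14 log units; that floor lies within the scatter) as an estimate that leans on a limit rather than a number. In this assay the estimate for compound 4 is 18000 nM with an expected range from 7000 nM to 25000 nM as the likely span.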

Compound 4, half-maximal effective concentration: > 25000 nM
Compound 4: a limit, no number; the forecaster's own chance of this, stated with the estimate: 60%; at least 1.3-fold (0.14 log units) between middle value and limit.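

Going by these compounds alone, compound 4 reads as a limit, as does compound 1, so no step from compound 1 to compound 4 can be read in this assay. Every value shown is such a limit: the limit of > 25000 nM in this assay, at which 4 of the 4 values shown sit.

The compounds shown leave open at what concentration any of them would reach the half-maximal effect, and whether tert-butyl in place of carbamoyl on an aromatic carbon changes it.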